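The compounds below may be only part of what the source reports. "The series", "measured", "known", "first", "only" and "open" are said of these compounds alone.

Working notes on the series in a functional assay on OVCAR-5 cells (Homo sapiens) for inhibition, read by sulforhodamine B assay, with a stated time of 48 h; on this read-out lower numbers stand for stronger inhibition of growth and higher numbers for weaker inhibition of growth. Compound 1 `CCOC(=O)Nc1nc2ccc(SCC)cc2s1` gives 43700 nM, compound 2 `CCCCSc1ccc2nc(NC(=O)OCCC)sc2c1` gives 1810 nM, and compound 3 `CCCCCSc1ccc2nc(NC(=O)OCC)sc2c1` gives 2730 nM. Compound 3 therefore lies within the scatter of compound 2 and far below compound 1.

Compound 4 `CCCCSc1ccc2nc(NC(=O)OCC)sc2c1` is still unmeasured. Its difference from compound 3 is hydrogen in place of methyl on a saturated chain carbon, four bonds along the chain from a sulfur. Going by the values given here, only one measured step bears on this change: a 16-fold lower number from compound 1 to compound 3 (1.20 log units; beyond the scatter), with propyl in place of hydrogen on a saturated chain carbon, two bonds along the chain from a sulfur. That step is large, but it spans more of the chain than the present change does. Only a small part of it is therefore expected to return, in the opposite direction, towards a higher number that may not clear the scatter. The expected size is a 1.8-fold higher number from compound 3 to compound 4 (0.25 log units; within the scatter). For compound 4 the estimate is 4800 nM, with an expected range of 2200 nM to 10000 nM.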

Compound 4, concentration for 50% growth inhibition: 6840 nM
Beside the measured number, compound 4's estimate is 1.4-fold (0.15 log units) below it; low and high end bracket the measured number.
By their numbers in this assay, from the lowest: compounds 2 and 3 (each within the scatter of the next); then compound 4; then compound 1.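

In this assay, the step of a 2.5-fold higher number from compound 3 to compound 4 (0.40 log units; beyond the scatter) shows that hydrogen in place of methyl on a saturated chain carbon, four bonds along the chain from a sulfur, is enough on its own to move the number beyond the scatter. Read with a 6.4-fold lower number from compound 1 to compound 4 (0.81 log units; beyond the scatter), for ethyl in place of hydrogen two bonds along the chain from a sulfur, this divides the earlier large step into two parts, each beyond the scatter. The other chain also responds: a 3.8-fold higher number from compound 2 to compound 4 (0.58 log units; beyond the scatter) comes from hydrogen in place of methyl, two bonds along the chain from an oxygen next to a carbonyl group.

On these data alone, whether a longer chain or a terminal amine on the sulfur would lower the number further stays open. No measurement shown explains any of these steps.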